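The source may report more compounds than this note shows. Statements on the series, on what has been measured and on what is new or still open speak of the compounds shown alone.

The measured compounds are:
compound 1 `COC(=O)c1c(O)c2ccccc2n(-c2ccccc2)c1=O`, which in a functional assay, with a stated time of 20 min, tested at 0.5 mM (a higher number here means a stronger effect of the compound at the concentration tested, a lower number a weaker effect), gives 16.8%;
compound 2 `NCCNC(=O)c1c(O)c2ccccc2n(-c2ccccc2)c1=O`, which in this assay gives 1.4%.

Compound 1 stands highest of the two numbers; its nearest neighbour is compound 2, which lies beyond the scatter below it. The step followed here leads from compound 1 to compound 3 `Nc1ccccc1NC(=O)c1c(O)c2ccccc2n(-c2ccccc2)c1=O`, which has not yet been measured in this assay. The change is (2-aminophenyl)amino in place of methoxy on a carbonyl carbon. Among the compounds with values here, one measured step bears on this: from compound 1 to compound 2 the methoxy on the carbonyl carbon was likewise replaced by an amino group, and that step was a number 15.4 percentage points lower from compound 1 to compound 2 (beyond the scatter). A step of similar direction, downward and of modest size, is therefore expected from compound 1 to compound 3, namely a number 10.8 percentage points lower from compound 1 to compound 3 (beyond the scatter). Compound 3 is accordingly estimated at 6%, with a range from 0% to 20%.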

Compound 3, a percentage reported as activity, at one concentration (the size of the read-out at that concentration, not a potency): 21.3%
Estimate against measurement, compound 3: 15.3 percentage points below; measured number above the stated range.
By their numbers in this assay, from the lowest: compound 2; then compounds 1 and 3 (each within the scatter of the next).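

Putting an amide in place of the ester does not by itself lower the read-out: in this assay the change to (2-aminophenyl)amino on this carbonyl carbon gives a number 4.5 percentage points higher from compound 1 to compound 3 (within the scatter), so compound 1 and compound 3 cannot be told apart. The group on the amide-type nitrogen matters instead, since 2-aminophenyl in place of 2-aminoethyl gives a number 19.9 percentage points higher from compound 2 to compound 3 (beyond the scatter), and the low read-out of compound 2 is therefore not common to both amides shown. Nothing available accounts for this difference between the two groups.

As far as these compounds go, it remains open whether the aromatic ring or its amino group carries the difference, which a plain phenylamino group on the carbonyl carbon would help to separate. Also open, from the compounds shown here alone, is how a carboxylic acid in place of the methoxy, or a longer aminoalkyl chain on the amide-type nitrogen, would read in this assay.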